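From phenyl to 1H-benzimidazol-2-yl: working notes on the series

A few compounds are considered here, and "the series" means these few. Any claim that something is new, unique, unknown or untested is made for them only; others in the source may bear on it.

Within the data shown here, in an ADME assay on HEK293 cells (Homo sapiens) for cytotoxicity, with a stated time of 72 h (a higher number here means that more compound is needed for the effect, a lower number that less compound is needed), compound 2 `O=C(Nc1cccc(-c2ccccc2)c1)c1cc([N+](=O)[O-])ccc1Cl` gives 22000 nM, the only actual number so far.

Compound 1 `O=C(Nc1cccc(-c2nc3ccccc3s2)c1)c1cc([N+](=O)[O-])c(O)cc1Cl` returns > 25000 nM, which is a limit of the assay and not a number.

Compound 3 `O=C(Nc1cccc(-c2nc3ccccc3[nH]2)c1)c1cc([N+](=O)[O-])ccc1Cl` is the next to be read. It carries 1H-benzimidazol-2-yl in place of phenyl on an aromatic carbon, meta to a large group: 1H-benzimidazol-2-yl in place of phenyl on an aromatic carbon.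

Among the measured compounds shown here, no pair of measured compounds differs in one place, so the size of this change has not been measured in this assay. The expectation rests on compound 2 at 22000 nM, and no clear direction is expected. The estimated step of a 1.1-fold lower number from compound 2 to compound 3 (0.04 log units; within the scatter) is expected to stay within the usual scatter. The readout also has a ceiling, (the limit of > 25000 nM in this assay, at which 1 of the 2 values shown sits), so compound 3 may be expected to return only a limit rather than a number.

For compound 3 the estimated value is 20000 nM, with an expected range of 9000 nM to 25000 nM.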

Compound 3, half-maximal effective concentration: > 27000 nM
Compound 3 was reported as a limit (the forecaster's own chance of this, stated with the estimate: 40%); middle value at least 1.3-fold (0.13 log units) from the limit.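

Placing 1H-benzimidazol-2-yl on this aromatic carbon instead of phenyl gives the first step in the series that can be read in this assay, an at least 1.2-fold higher number from compound 2 to compound 3 (0.08 log units; that floor lies within the scatter). Going by these compounds, compound 3 gives > 27000 nM, which is a limit of the assay and not a number, so the step is only a floor and its true size remains unknown. The position therefore accepts the larger group, with its hydrogen-bond donor and acceptor, without a value for compound 3 appearing inside the measured range, and the upper end of the read-out restricts what this comparison can show: the limit of > 27000 nM in this assay, at which 1 of the 3 values shown sits.

On these data alone, it remains open whether the real gap from compound 2 to compound 3 is small or large, since the data set only its lower bound. Also open, as far as these compounds go, is how this position would read with an amine or a carboxylic acid on the same aromatic carbon in place of phenyl, and whether either would give an actual number rather than a limit.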